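Swapping the Ring at the Chain End: Expecting Compound 4

The compounds below may be only part of what the source reports. "The series", "measured", "known", "first", "only" and "open" are said of these compounds alone.

Measured so far in this assay:
compound 1, `COc1ccc(/C=C/C(=O)c2ccccc2NC(=O)NS(=O)(=O)c2ccc(C)cc2)cc1OC`: 12.9 ug/mL
compound 2, `COc1ccc(/C=C/C(=O)c2ccccc2NC(=O)NS(=O)(=O)c2ccc(C)cc2)c(OC)c1`: 16 ug/mL
compound 3, `COc1cc(/C=C/C(=O)c2ccccc2NC(=O)NS(=O)(=O)c2ccc(C)cc2)ccc1O`: 17.8 ug/mL

All three compounds share one core and differ only in the aromatic ring at the end of the double-bonded chain. In an ADME assay on the whole organism for cytotoxicity, with Artemia salina as the target, with a stated time of 24 h (on this read-out higher numbers stand for an effect only at larger amounts of compound and lower numbers for an effect already at smaller amounts), compound 1 gives 12.9 ug/mL, compound 2 gives 16 ug/mL, and compound 3 gives 17.8 ug/mL. The steps between them are small: a 1.2-fold higher number from compound 1 to compound 2 (0.09 log units; within the scatter), a 1.4-fold higher number from compound 1 to compound 3 (0.14 log units; within the scatter), and a 1.1-fold higher number from compound 2 to compound 3 (0.05 log units; within the scatter). Compound 3 therefore stands among its two neighbours with no separation that can be trusted; the three numbers are, for practical purposes, one number.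

Compound 4, `Cc1ccc(S(=O)(=O)NC(=O)Nc2ccccc2C(=O)/C=C/c2ccccc2Cl)cc1`, keeps the core and changes the ring again: 2-chlorophenyl in place of 4-hydroxy-3-methoxyphenyl on a double-bonded chain carbon bound to a double-bonded chain carbon. The three measured steps bear on this only indirectly. Each of them also altered the groups on that same ring, and each stayed within the scatter, but none of them removed both oxygen groups or brought in a chlorine, so the change to compound 4 is larger than anything measured here. Among the compounds with values here, with that caveat, the only guidance available is that changes on this ring have so far not moved the number, and the step is expected to be a 1.1-fold lower number from compound 3 to compound 4 (0.05 log units; within the scatter), that is, none beyond the scatter. Compound 4 is estimated at 16 ug/mL, within a range of 7 ug/mL to 38 ug/mL.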

Compound 4, concentration for half-maximal effect: 12.8 ug/mL
Compound 4: the middle estimate sits 1.3-fold (0.10 log units) above what was measured, within the range that was stated.
By their numbers in this assay, from the lowest: compounds 4, 1, 2 and 3 (each within the scatter of the next).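

In this assay, putting 2-chlorophenyl in place of the earlier rings on a double-bonded chain carbon bound to a double-bonded chain carbon gives a 1.4-fold lower number from compound 3 to compound 4 (0.14 log units; within the scatter) and a 1.3-fold lower number from compound 2 to compound 4 (0.10 log units; within the scatter) and also a 1.0-fold lower number from compound 1 to compound 4 (0.00 log units; within the scatter) for the three comparisons. The earlier steps shown here only exchanged rings that carried oxygen groups, whereas this one brings in a ring with chlorine and no oxygen, and the number still does not separate from the others, so all four compounds read as one level at this position. No measurement at hand explains why the number stays so flat.

The four compounds leave open whether this flatness holds for very different groups on this ring, such as an amine or a carboxylic acid, or for a plain phenyl ring with no group on it at all. They also leave open what a longer chain in place of the ring would do, and whether changes elsewhere on the shared core would move the number when changes at this position do not.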